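From methyl to methoxy on compound 2

This account rests on a few compounds, and the source may have more. Where it says the series, first, only, none or still open, it means among the compounds named here.

Of the compounds shown here, two have been measured so far. In an ADME assay on Huh-7 cells (Homo sapiens) for cytotoxicity, read by thymidine incorporation (a higher number here means that more compound is tolerated, a lower number that less compound is tolerated), compound 1 `COC(=O)N[C@H](C(=O)N1CCC[C@H]1c1nc2ccc(-c3ccc(-c4ccc5nc([C@@H]6CCCN6C(=O)[C@@H](NC(=O)OC)C(C)C)[nH]c5c4)s3)cc2[nH]1)C(C)C` gives 6000 nM and compound 2 `COC(=O)N[C@H](C(=O)N1CCC[C@H]1c1nc2cc(-c3ccc(-c4ccc5[nH]c([C@@H]6CCCN6C(=O)[C@@H](NC(=O)OC)C(C)C)nc5c4)c(C)c3)ccc2[nH]1)C(C)C` gives 3000 nM as the half-maximal cytotoxic concentration. These two numbers lie within the usual scatter of each other, so compound 2 stands level with compound 1 on this evidence.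

Compound 3 `COC(=O)N[C@H](C(=O)N1CCC[C@H]1c1nc2cc(-c3ccc(-c4ccc5[nH]c([C@@H]6CCCN6C(=O)[C@@H](NC(=O)OC)C(C)C)nc5c4)c(OC)c3)ccc2[nH]1)C(C)C` keeps the structure of compound 2 apart from one change: methoxy in place of methyl on an aromatic carbon, ortho to a large group and meta to a large group (methoxy in place of methyl on an aromatic carbon). Among the compounds with values here, no measured pair differs in a single place, so no direct precedent exists for the size of this step. Within the data shown here, the only guide is the narrow spread of the two values, with compound 1 at 6000 nM and compound 2 at 3000 nM in this assay. No step beyond the scatter is therefore expected, in either direction. The estimated change is a 1.2-fold higher number from compound 2 to compound 3 (0.07 log units; within the scatter) and stays inside that scatter. Compound 3 is expected to give about 3500 nM with an estimated range from 1500 nM to 9000 nM when it is measured.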

Compound 3, half-maximal cytotoxic concentration: 6000 nM
Estimate against measurement, compound 3: 1.7-fold (0.23 log units) below, within the range that was stated.
By their numbers in this assay, from the lowest: compounds 2, 1 and 3 (each within the scatter of the next).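

Within the data shown here, this is the first comparison in which only one place differs, and so the first that puts a size on a change at this position. In this assay, among these compounds, methoxy in place of methyl on an aromatic carbon, ortho to a large group and meta to a large group, gives a 2.0-fold higher number from compound 2 to compound 3 (0.30 log units; within the scatter) and leaves compound 2 and compound 3 level on this evidence, so the extra heavy atom and the hydrogen-bond acceptor that enter with methoxy come with no step that can be read beyond the scatter. Nothing measured here bears on why the step has this size, and no explanation can be offered for it.

What an amine, a carboxylic acid or a longer chain would do on this same aromatic carbon stays open, since methyl and methoxy are the only two groups shown there. From the compounds shown here alone, it also stays open whether methoxy in place of methyl would remain within the scatter elsewhere on the shared core, as a single step at a single position cannot answer that.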